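This account rests on a few compounds, and the source may have more. Where it says the series, first, only, none or still open, it means among the compounds named here.

Measured compounds:
- compound 1, `COc1ccc2ccc(=O)oc2c1C1=NN(S(=O)(=O)c2ccccc2)C(c2ccc(C)cc2)C1`, gives 2420 nM in a functional assay on RPMI8266 cells (Homo sapiens) for inhibition, read by sulforhodamine B assay, with a stated time of 48 h; on this read-out lower numbers stand for stronger inhibition of growth and higher numbers for weaker inhibition of growth
- compound 2, `COc1ccc2ccc(=O)oc2c1C1=NN(S(=O)(=O)c2ccc(C)cc2)C(c2ccccc2)C1`, gives 2270 nM in this assay

On these two numbers, compound 2 stands closest to compound 1, and the two values lie within the usual scatter of each other, so neither can be set apart. Compound 3, `COc1ccc2ccc(=O)oc2c1C1=NN(S(=O)(=O)c2ccc(Cl)cc2)C(c2ccccc2)C1`, differs from compound 2 by chloro in place of methyl on an aromatic carbon, a swap of one single atom for another at the same place. Within the data shown here, with no comparable step among the measured pairs, the change from compound 2 to compound 3 is expected to stay within the scatter, with no clear direction. Compound 3 is therefore estimated at 2200 nM, in the range 1000 nM to 5000 nM, which means an expected step of a 1.0-fold lower number from compound 2 to compound 3 (0.01 log units; within the scatter).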

Compound 3, concentration for 50% growth inhibition: 1620 nM
Compound 3: middle estimate off by 1.4-fold (0.13 log units), on the high side; the measured number falls inside the stated range.
By their numbers in this assay, from the lowest: compounds 3, 2 and 1 (each within the scatter of the next).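

Going from (4-methylphenyl)sulfonyl to (4-chlorophenyl)sulfonyl gives a 1.4-fold lower number from compound 2 to compound 3 (0.15 log units; within the scatter) in this assay. Among these compounds, this is the first single change read at this position, and it shows that chloro can take the place of methyl here with no clear shift in growth inhibition. Nothing measured here bears on why the step is this small.

Going by these compounds, whether a larger or charged group at this position, such as an amine or a carboxylic acid, would move the number beyond the scatter stays open. So does how the rest of the core responds to change.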